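This account rests on a few compounds, and the source may have more. Where it says the series, first, only, none or still open, it means among the compounds named here.

Compound 1 `Cc1oc(=O)oc1COC(=O)c1cccc(NC(=O)[C@@H]2C[C@H](SC3=C(C(=O)O)N4C(=O)[C@H]([C@@H](C)O)[C@H]4[C@H]3C)CN2)c1` was examined in a physicochemical assay for metabolic stability, read by LC-MS, in phosphate buffer, with a stated time of 3 h, at pH 7.4, tested at 50 uM; on this read-out lower numbers stand for a less stable compound and higher numbers for a more stable compound. In this assay compound 1 gives > 95%, which is a limit of the assay and not a number. Compound 2 `CC(C)OC(=O)c1cccc(NC(=O)[C@@H]2C[C@H](SC3=C(C(=O)O)N4C(=O)[C@H]([C@@H](C)O)[C@H]4[C@H]3C)CN2)c1` differs from compound 1 in one place: a group of 3 heavy atoms (3 carbon; no ring) stands in place of a group of 8 heavy atoms (5 carbon, 3 oxygen; one five-membered aromatic ring with 2 hetero atoms), on an oxygen next to a carbonyl group. In this assay compound 2 gives > 95%, likewise a limit. The step that the two limits leave unreadable from compound 1 to compound 2 cannot be read because of the limit of > 95% in this assay, at which 2 of the 2 values shown sit.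

Compound 3 `Cc1oc(=O)oc1COC(=O)C1=C(S[C@@H]2CN[C@H](C(=O)Nc3cccc(C(=O)OCc4oc(=O)oc4C)c3)C2)[C@H](C)[C@@H]2[C@@H]([C@@H](C)O)C(=O)N12` has not been measured. It differs from compound 1 by a group of 8 heavy atoms (5 carbon, 3 oxygen; one five-membered aromatic ring with 2 hetero atoms) in place of a hydrogen atom, on an oxygen next to a carbonyl group; the entering group carries 1 double bond outside aromatic rings, no hydrogen-bond donors and 3 hydrogen-bond acceptors, and sits on an oxygen next to a carbonyl group whose other neighbour is a carbonyl carbon. Within the data shown here, the only measured step that bears on this change is the one from compound 1 to compound 2, and its size is not readable. The expected step in this assay is a number at least 5 percentage points lower from compound 1 to compound 3 (that floor lies within the scatter). For compound 3 the estimate is 90%, with a range from 60% to 98%.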

Compound 3, percent of the compound remaining: > 95%
Compound 3: a limit, no number; the forecaster's own chance of this, stated with the estimate: 50%; at least 5 percentage points between middle value and limit.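

In this assay compound 3 gives > 95% as a limit of the assay and not a number. No new step can be read between compound 1 and compound 3 because all the values shown sit at one limit: the limit of > 95% in this assay, at which 3 of the 3 values shown sit.

As far as these compounds go, how far either ester group on the oxygen changes the percent remaining in this assay stays open.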